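A few compounds are considered here, and "the series" means these few. Any claim that something is new, unique, unknown or untested is made for them only; others in the source may bear on it.

Measured compounds:
Compound 1 `Cc1ccc(Nc2nc(-c3cc(C(F)(F)F)ccc3F)cs2)cc1` gives 24000 nM in a physicochemical assay for solubility, read by LC-MS, measured as kinetic solubility, with a stated time of 4 h; a lower number here means a less soluble compound, a higher number a more soluble compound.
Compound 2 `COc1ccc(-c2csc(Nc3ccc(C)cc3)n2)cc1` gives 20000 nM in this assay.
Compound 3 `CCOC(=O)c1cc(-c2csc(Nc3ccc(C)cc3)n2)on1` gives 54900 nM in this assay.

Among these three, compound 3 shows the highest number, and its distance from compound 1 as well as from compound 2 lies beyond the usual scatter, so it stands as the most soluble of the set. Compound 4 `Cc1ccc(Nc2nc(-c3cc(C(=O)Nc4ccccn4)no3)cs2)cc1` keeps the shared core and differs from compound 3 in one place: (pyridin-2-yl)amino in place of ethoxy on a carbonyl carbon. Going by the values given here, no pair of measured compounds shows this kind of change, so there is no measured step to lean on. The change is expected to lower the number, by a step of a 3.7-fold lower number from compound 3 to compound 4 (0.56 log units; beyond the scatter). Compound 4 is therefore estimated at 15000 nM, within a range from 4000 nM to 50000 nM.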

Compound 4, solubility: 2900 nM
Estimate against measurement, compound 4: 5.2-fold (0.71 log units) above; the measured number lies below the stated range.
By their numbers in this assay, from the lowest: compound 4; then compounds 2 and 1 (each within the scatter of the next); then compound 3.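

In this assay, going by these compounds alone, putting (pyridin-2-yl)amino in place of ethoxy on a carbonyl carbon gives a 19-fold lower number from compound 3 to compound 4 (1.28 log units; beyond the scatter) and is the first step that can be read in this set. This large step shows that a single change at this carbonyl carbon can move the number far beyond the scatter. Nothing measured here bears on the reason for the step.

The compounds shown leave open which part of the entering group goes with the step. A methylamino group on the same carbonyl carbon, with no ring, could separate the effect of the ring from that of the amide hydrogen.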